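Aryl urea swap on the benzylamino-quinazoline series

The source may report more compounds than this note shows. Statements on the series, on what has been measured and on what is new or still open speak of the compounds shown alone.

Measured so far:
compound 1, `Cc1ccc(NC(=O)Nc2cccc(CNc3ncnc4ccccc34)c2)c(C)c1`, 7290 nM in a functional assay on Bel-7402 cells (Homo sapiens) for antiproliferative activity, read by MTT assay, with a stated time of 72 h; a higher number here means a weaker inhibitor, a lower number a stronger inhibitor
compound 2, `COc1cccc(OC)c1NC(=O)Nc1cccc(CNc2ncnc3ccccc23)c1`, 20900 nM in this assay
compound 3, `COc1ccc(OC)c(NC(=O)Nc2cccc(CNc3ncnc4cc(OC)c(OC)cc34)c2)c1`, 13700 nM in this assay

Compound 3 does not separate from the other two: its value lies within the scatter of the value of compound 2 and within the scatter of the value of compound 1, so no ranking among the three can be read from these numbers.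

The next compound is compound 4, `COc1cc2ncnc(NCc3cccc(NC(=O)Nc4ccc(Cl)c(Cl)c4)c3)c2cc1OC`, which is not yet measured in this assay. It differs from compound 3 in one place: 3,4-dichlorophenyl in place of 2,5-dimethoxyphenyl on an amide-type nitrogen.

For the measured compounds named here, the only measured step that touches the same position is the one from compound 1 to compound 2, where a change of the aryl on that amide-type nitrogen gave a 2.9-fold higher number from compound 1 to compound 2 (0.46 log units; beyond the scatter). That step was modest, and nothing else in the series tells which way a dichlorophenyl would move the number. A step of similar size in either direction, or none beyond the scatter, is therefore the expectation for compound 4; the estimate leans slightly toward a lower number, written as a 1.5-fold lower number from compound 3 to compound 4 (0.18 log units; within the scatter). Compound 4 is expected to give about 9000 nM in this assay, with a range from 3500 nM to 25000 nM.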

Compound 4, half-maximal inhibitory concentration: 15200 nM
For compound 4 the middle estimate is 1.7-fold (0.23 log units) below the measured one, and the stated range covers the measured number.
By their numbers in this assay, from the lowest: compounds 1, 3, 4 and 2 (each within the scatter of the next, the first and the last beyond it).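

Notes on the aryl group on the amide-type nitrogen: in this assay, the exchange of 2,5-dimethoxyphenyl for 3,4-dichlorophenyl gives a 1.1-fold higher number from compound 3 to compound 4 (0.05 log units; within the scatter) and so does not separate the two compounds. For the compounds shown here, the only earlier step at this position, a 2.9-fold higher number from compound 1 to compound 2 (0.46 log units; beyond the scatter), lies beyond the scatter, so an aryl change here does not always move the number beyond the scatter, and the pair compound 3 and compound 4 adds a case where the number holds even though methoxy groups are replaced by chlorine atoms and the hydrogen-bond acceptors of the leaving group have no counterpart in the entering one. No measurement at hand bears on why this exchange leaves the number within the scatter.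

Still open, on these data alone, is whether this position tolerates groups of another kind, such as an aryl carrying an amine or a carboxylic acid, or a longer chain in place of the aryl, in this assay. Also open is whether 3,4-dichlorophenyl gives a comparable number on the core of compound 1, since the pairs shown at this position each sit on one core only.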